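Triazole acetamide series: splenocyte cytotoxicity notes

A few compounds are considered here, and "the series" means these few. Any claim that something is new, unique, unknown or untested is made for them only; others in the source may bear on it.

Measured so far:
compound 1 `O=C(Cn1cc(CCCCO)nn1)NCc1ccccc1` — 1700 uM
compound 2 `O=C(Cn1cc(C(=O)O)nn1)NCc1ccccc1` — "non-toxic" (no number reported)
compound 3 `O=C(O)CCc1cn(CC(=O)NCc2ccccc2)nn1` — 1420 uM

In an ADME assay on cells (spleen, Mus musculus, strain C57BL/6) for inhibition, read by flow cytometry and propidium iodide staining, with a stated time of 24 h, at 37 degrees C (on this read-out higher numbers stand for an effect only at larger amounts of compound and lower numbers for an effect already at smaller amounts), compound 1 gives 1700 uM. Compound 3 gives 1420 uM, and the step of a 1.2-fold lower number from compound 1 to compound 3 (0.08 log units; within the scatter) leaves the two within the scatter of each other. Compound 2 is reported as "non-toxic" (no number reported), without a number, so it gives no position for compound 1 to be set against.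

Compound 4 `O=C(Cn1cc(-c2cccc(F)c2)nn1)NCc1ccccc1` differs from compound 1 by 3-fluorophenyl in place of 4-hydroxybutyl on an aromatic carbon. Within the data shown here, no measured step touches this position with a ring group; the one measured step, a 1.2-fold lower number from compound 1 to compound 3 (0.08 log units; within the scatter), changed a chain end and stayed within the scatter. For compound 4 the expected step is a 1.9-fold lower number from compound 1 to compound 4 (0.28 log units; within the scatter), a modest move that may not exceed the scatter. Compound 4 is therefore estimated at 900 uM, with a range from 300 uM to 2200 uM.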

Compound 4, concentration for half-maximal effect: "non-toxic" (no number reported)
Nothing numeric was reported for compound 4; the estimate stays without a comparison.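

Compound 4 is reported as "non-toxic" without a number, so no new step can be read against compound 1. The compounds shown leave open how 3-fluorophenyl compares numerically with 4-hydroxybutyl at this place. No evidence at hand bears on this result.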